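The compounds below may be only part of what the source reports. "The series", "measured", "known", "first", "only" and "open" are said of these compounds alone.

Compound 2 `COc1ccc(S(=O)(=O)c2nc3ccccc3nc2N2CCc3ccccc3C2)cc1` shares its core with compound 1 `Cc1ccc(S(=O)(=O)c2nc3ccccc3nc2N2CCc3ccccc3C2)cc1`. In a functional assay on PC-3 cells (Homo sapiens) for cytotoxicity, read by MTT assay, with a stated time of 72 h (a lower number here means a stronger inhibitor, a higher number a weaker inhibitor), compound 1 gives 22400 nM. Compound 2 reaches only a limit in this assay, > 50000 nM, the same as the limit of > 50000 nM in this assay, at which 1 of the 2 values shown sits. Among the measured compounds shown here, the single measured step, an at least 2.2-fold higher number from compound 1 to compound 2 (0.34 log units; beyond the scatter), exchanges methyl for methoxy on the aromatic carbon. Compound 3 `O=S(=O)(c1ccc(F)cc1)c1nc2ccccc2nc1N1CCc2ccccc2C1` differs from compound 2 by fluoro in place of methoxy on an aromatic carbon. For the measured compounds named here, no measured step involves fluoro, so the evidence is thin; the only guide is that the methoxy compound sits weaker in an at least 2.2-fold higher number from compound 1 to compound 2 (0.34 log units; beyond the scatter). Compound 3 is therefore expected near 25000 nM, between 8000 nM and 80000 nM. That estimate implies an expected at least 2.0-fold lower number from compound 2 to compound 3 (0.30 log units; that floor lies within the scatter).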

Compound 3, half-maximal inhibitory concentration: 9230 nM
Beside the measured number, compound 3's estimate is 2.7-fold (0.43 log units) above it; low and high end bracket the measured number.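

In this assay, the change from 4-methoxyphenyl to 4-fluorophenyl gives an at least 5.4-fold lower number from compound 2 to compound 3 (0.73 log units; beyond the scatter). As far as these compounds go, compound 2 stands only at a limit, so the true size of that step stays unknown: the limit of > 50000 nM in this assay, at which 1 of the 3 values shown sits. Fluoro in place of methyl gives a 2.4-fold lower number from compound 1 to compound 3 (0.39 log units; beyond the scatter), so at this place, para to a large group, the number now moves both ways from methyl, with methoxy weaker and fluoro stronger. The compounds shown leave open whether chloro, trifluoromethyl or an amine at this place would go beyond fluoro.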